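Compound 3 at the clearance limit: swapping its benzoxazole

The source may hold more compounds than are shown below. What is called first, only, known or untested is meant among the compounds shown, and "the series" means these compounds.

In an ADME assay (liver) for metabolic stability, with Liver microsome (Homo sapiens) as the target, using microsomes and NADPH, with a stated time of 30 min, tested at 1 uM (a lower number here means slower removal, a higher number faster removal of the compound), compound 3 `Nc1ccc(S(=O)(=O)N2CCN(c3ncc(C(O)(C(F)(F)F)C(F)(F)F)cc3-c3ccc4ocnc4c3)CC2)cn1` gives < 14 mL.min-1.g-1, which is a limit of the assay and not a number. Compound 1 `Nc1ccc(S(=O)(=O)N2CCN(c3ncc(C(O)(C(F)(F)F)C(F)(F)F)cc3C#CCO)CC2)cn1` gives < 14 mL.min-1.g-1, also a limit. Compound 2 `CS(=O)(=O)c1ccc(-c2cc(C(O)(C(F)(F)F)C(F)(F)F)cnc2N2CCN(S(=O)(=O)c3ccc(N)nc3)CC2)cc1` gives a measured 32 mL.min-1.g-1. Much of the comparison is bounded by the limit of < 14 mL.min-1.g-1 in this assay, at which 2 of the 3 values shown sit.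

Compound 4 `Nc1ccc(S(=O)(=O)N2CCN(c3ncc(C(O)(C(F)(F)F)C(F)(F)F)cc3-c3cccc4[nH]ncc34)CC2)cn1` carries 1H-indazol-4-yl in place of 1,3-benzoxazol-5-yl on an aromatic carbon. Among the measured compounds shown here, no measured step tests 1H-indazol-4-yl directly. The nearest evidence comes from changes at the same place. These gave an at least 2.2-fold higher number from compound 1 to compound 2 (0.35 log units; beyond the scatter) and an at least 2.2-fold lower number from compound 2 to compound 3 (0.35 log units; beyond the scatter), while the remaining comparison is a step that the two limits leave unreadable from compound 1 to compound 3. Those steps show that this place can move the number in this assay beyond the scatter, but they do not fix a direction for the new group. The expectation therefore rests on compound 3 and its limit of < 14 mL.min-1.g-1.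

The expected change is an at least 1.0-fold higher number from compound 3 to compound 4 (0.02 log units; that floor lies within the scatter), with no step beyond the scatter anticipated. For compound 4 the estimated value is 15 mL.min-1.g-1. The expected range for compound 4 runs from 9 mL.min-1.g-1 to 32 mL.min-1.g-1.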

Compound 4, intrinsic clearance in microsomes: 42 mL.min-1.g-1
Compound 4: middle estimate off by 2.8-fold (0.45 log units), on the low side, outside the stated range (above it).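

At this position, the change from 1,3-benzoxazol-5-yl to 1H-indazol-4-yl, a group with the same ring types that carries a hydrogen-bond donor, gives in this assay an at least 3.0-fold higher number from compound 3 to compound 4 (0.47 log units; beyond the scatter). The earlier compounds had not shown that two groups with the same ring types can differ beyond the scatter here. Set against the other substituents, 1H-indazol-4-yl gives a 1.3-fold higher number from compound 2 to compound 4 (0.12 log units; within the scatter) and an at least 3.0-fold higher number from compound 1 to compound 4 (0.47 log units; beyond the scatter), so a fast-cleared compound need not carry 4-(methylsulfonyl)phenyl.

As far as these compounds go, the full size of the steps from compound 1 and compound 3 stays open, since each starts from a limit: the limit of < 14 mL.min-1.g-1 in this assay, at which 2 of the 4 values shown sit. From the compounds shown here alone, whether the rise follows the indazole hydrogen or the arrangement of the ring atoms is also open, and a 1-methyl-1H-indazol-4-yl group would bear on that question.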